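Changing the group on the carbonyl carbon of a shared core

A few compounds are considered here, and "the series" means these few. Any claim that something is new, unique, unknown or untested is made for them only; others in the source may bear on it.

The shared core carries a variable group on a carbonyl carbon. In a functional assay on isolated protein for inhibition of Glucose-dependent insulinotropic receptor (Rattus norvegicus), read by HTRF and cAMP accumulation (a lower number here means a smaller maximal response, a higher number a larger maximal response), compound 3 `Cc1nc(S(C)(=O)=O)ccc1Oc1ncnc(OC2CCN(C(=O)C(C)(F)F)CC2)c1F` gives 87%, the top number of three, though only just: compound 1 `Cc1nc(S(C)(=O)=O)ccc1Oc1ncnc(OC2CCN(C(=O)OC(C)C)CC2)c1F` gives 77%, and a number 10 percentage points higher from compound 1 to compound 3 (within the scatter) lies within the scatter, whereas compound 2 `Cc1nc(S(C)(=O)=O)ccc1Oc1ncnc(OC2CCN(C(=O)OC3COC3)CC2)c1F` gives 66% and a number 21 percentage points higher from compound 2 to compound 3 (beyond the scatter) lies beyond it. Compound 4 `Cc1nc(S(C)(=O)=O)ccc1Oc1ncnc(OC2CCN(C(=O)c3noc(C(C)(C)F)n3)CC2)c1F` is not yet measured. It differs from compound 3 on the carbonyl carbon: a group of 9 heavy atoms (5 carbon, 2 nitrogen, 1 oxygen, 1 fluorine; one five-membered aromatic ring with 3 hetero atoms) in place of a group of 4 heavy atoms (2 carbon, 2 fluorine; no ring), on a carbonyl carbon. For the measured compounds named here, the steps that bear on this are a number 10 percentage points higher from compound 1 to compound 3 (within the scatter) and a number 21 percentage points higher from compound 2 to compound 3 (beyond the scatter), both exchanges on that same carbon, yet none introduced an aromatic ring. Compound 4 is therefore expected to move little, a step of a number 7 percentage points lower from compound 3 to compound 4 (within the scatter). Compound 4 is estimated at 80%, ranging from 62% to 96%.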

Compound 4, largest response reached (reported as efficacy), in percent of the reference or control that the assay uses: 74%
The estimate for compound 4 lay 6 percentage points above the measured number; the range from low to high includes it.
By their numbers in this assay, from the lowest: compounds 2, 4, 1 and 3 (each within the scatter of the next, the first and the last beyond it).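

A five-membered aromatic ring with 3 hetero atoms on the carbonyl carbon still leaves a clear response in this assay, although a number 13 percentage points lower from compound 3 to compound 4 (beyond the scatter). Against the two oxygen-linked groups the ring group cannot be told apart, with a number 8 percentage points higher from compound 2 to compound 4 (within the scatter) and a number 3 percentage points lower from compound 1 to compound 4 (within the scatter). Nothing measured here explains these numbers. The compounds shown leave open whether the fluorine on the ring group's side chain matters, and how a plain phenyl ring or an amine such as dimethylamino on that carbonyl carbon would read.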